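Phenyl for 2,4-Dichlorophenyl with Both Parents at the Limit

A few compounds are considered here, and "the series" means these few. Any claim that something is new, unique, unknown or untested is made for them only; others in the source may bear on it.

Compound 2 `O=c1ccoc2cc(OCc3cn(Cc4ccc(Cl)cc4Cl)nn3)ccc12` is measured in a functional assay on SGC-7901 cells (Homo sapiens) for cytotoxicity, read by MTT assay, with a stated time of 48 h (on this read-out lower numbers stand for stronger inhibition and higher numbers for weaker inhibition), only as a limit, > 100000 nM. Compound 1 `O=c1ccoc2cc(OCc3cn(Cc4ccc([N+](=O)[O-])cc4)nn3)ccc12` likewise reaches only a limit in this assay, > 100000 nM. The step that the two limits leave unreadable from compound 1 to compound 2 is therefore unreadable, and both values sit at the limit of > 100000 nM in this assay, at which 2 of the 2 values shown sit. Compound 3 `O=c1ccoc2cc(OCc3cn(Cc4ccccc4)nn3)ccc12` differs from compound 2 by phenyl in place of 2,4-dichlorophenyl on a saturated chain carbon bound to an aromatic nitrogen. No readable step bears on this change, and the two limits give no direction for it. Compound 3 is expected to stay at the limit as well, with a step that the limit leaves unreadable from compound 2 to compound 3 estimated to show no readable change. The estimate for compound 3 in this assay is 150000 nM, in a range from 40000 nM to 600000 nM.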

Compound 3, half-maximal inhibitory concentration: > 100000 nM
Compound 3 ended at the assay's limit; the forecaster's own chance of this, stated with the estimate: 85%; the middle value does not contradict the limit.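

Compound 3 gives > 100000 nM in this assay, which is a limit and not a number. No step from compound 1 or compound 2 to compound 3 can be read: the limit of > 100000 nM in this assay, at which 3 of the 3 values shown sit.

The compounds shown leave open how these three rank and which change to the shared core or its side group would give a readable value in this assay.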